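The source may hold more compounds than are shown below. What is called first, only, known or untested is meant among the compounds shown, and "the series" means these compounds.

Compound 2 `COc1nn(C)c2nc(N)nc(NS(=O)(=O)c3cccc(Cl)c3Cl)c12` carries an amino group on the shared core. Among the measured compounds shown here, in a functional assay on cells for antagonist activity at C-C chemokine receptor type 4 (Homo sapiens), read by GTPgammaS binding (on this read-out higher numbers stand for weaker inhibition and lower numbers for stronger inhibition), compound 2 gives 316 nM, the lower of the two numbers measured so far. Its nearest neighbour, compound 1 `COc1nc(NS(=O)(=O)c2cccc(Cl)c2Cl)c2c(OC)nn(C)c2n1`, carries a methoxy group in place of that amino group, and in this assay compound 1 gives 794 nM; the step of a 2.5-fold lower number from compound 1 to compound 2 (0.40 log units; beyond the scatter) is modest yet beyond the scatter. Compound 3 `CNc1nc(NS(=O)(=O)c2cccc(Cl)c2Cl)c2c(OC)nn(C)c2n1` differs from compound 2 by methyl in place of hydrogen on a nitrogen on an aromatic ring. For the measured compounds named here, only one measured step bears on this change, and it concerns the exchange of a whole group rather than a methyl added to the nitrogen, so it offers little direct guidance. The expected step is therefore a 1.1-fold higher number from compound 2 to compound 3 (0.04 log units; within the scatter), which amounts to none beyond the scatter. The estimate for compound 3 in this assay is 350 nM, with a range from 130 nM to 950 nM.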

Compound 3, half-maximal inhibitory concentration in the C-C chemokine receptor type 4 assay: 79.4 nM
Compound 3: middle estimate off by 4.4-fold (0.64 log units), on the high side, outside the stated range (below it).
By their numbers in the C-C chemokine receptor type 4 assay, from the lowest: compound 3; then compound 2; then compound 1.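

In the C-C chemokine receptor type 4 assay, adding a single methyl to the amino nitrogen gives a 4.0-fold lower number from compound 2 to compound 3 (0.60 log units; beyond the scatter), so this position accepts at least this small group and inhibition becomes stronger. Exchanging methoxy for methylamino on the same aromatic carbon gives a 10-fold lower number from compound 1 to compound 3 (1.00 log units; beyond the scatter), which puts methylamino ahead of both amino and methoxy among these three compounds. In a physicochemical assay for lipophilicity (a higher number here means a more lipophilic compound, a lower number a more polar compound), compound 2 gives 2.4 and compound 3 gives 3.2. The stronger inhibition by compound 3 may be linked to this higher number, although a single pair cannot separate the two: the measured distribution coefficient of compound 2, 2.4, and of compound 3, 3.2, a number 0.80 log units higher (beyond the scatter)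

On these data alone, it remains open whether an ethyl group or a longer chain on this nitrogen would strengthen inhibition further or weaken it. A dimethylamino group would show whether the remaining hydrogen on the nitrogen matters, and a hydroxyethyl chain would test whether inhibition can be kept with a more polar group.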